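Cytotoxicity notes on compounds 2 and 3

This account rests on a few compounds, and the source may have more. Where it says the series, first, only, none or still open, it means among the compounds named here.

Compound 1 `N#Cc1c(-c2ccccc2)nc(Nc2ccc(Cl)cc2)nc1N1CCCCC1` and compound 2 `N#Cc1c(NC2CCCCC2)nc(SCc2ccccc2)nc1-c1ccc(Cl)cc1` have both been run in an ADME assay on Jurkat cells (Homo sapiens) for cytotoxicity, read by WST assay, with a stated time of 48 h; on this read-out lower numbers stand for higher toxicity in this test and higher numbers for lower toxicity in this test. For compound 1 the result is a limit of the assay, > 10000 nM. For compound 2 as well only a limit of the assay is known, > 10000 nM. For the measured compounds named here, compound 2 therefore stands exactly where every value so far sits: the limit of > 10000 nM in this assay, at which 2 of the 2 values shown sit. Compound 3 `N#Cc1c(-c2ccc(Cl)cc2)nc(SCc2ccccc2)nc1N1CCC(C(N)=O)CC1` differs from it by 4-carbamoylpiperidin-1-yl in place of cyclohexylamino on an aromatic carbon. Going by the values given here, no measured step links the two compounds in this assay; the step expected, a step that the limit leaves unreadable from compound 2 to compound 3, is none beyond the usual scatter. Compound 3 is accordingly estimated at 15000 nM, within 6000 nM to 40000 nM.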

Compound 3, half-maximal cytotoxic concentration: > 10000 nM
Compound 3: no number, only a limit (the forecaster's own chance of this, stated with the estimate: 80%); the middle value does not contradict the limit.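

For the compounds shown here, compound 3 gives > 10000 nM in this assay and this is a limit of the assay, as it is for compound 2, so no step from compound 2 to compound 3 can be read. Still open is the concentration at which any of these compounds turns cytotoxic, and whether 4-carbamoylpiperidin-1-yl in place of cyclohexylamino shifts it.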